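The source may hold more compounds than are shown below. What is called first, only, known or untested is meant among the compounds shown, and "the series" means these compounds.

Of the compounds shown here, three of one family have been measured in an ADME assay on the whole organism for cytotoxicity, with Artemia salina as the target, with a stated time of 24 h; on this read-out lower numbers stand for an effect already at smaller amounts and higher numbers for an effect only at larger amounts of compound. Compound 1 `COc1ccc(/C=C/C(=O)c2ccccc2NC(=O)NS(=O)(=O)c2ccc(C)cc2)cc1` gives 28.1 ug/mL. Compound 2 `Cc1ccc(S(=O)(=O)NC(=O)Nc2ccccc2C(=O)/C=C/c2ccc(O)cc2)cc1` gives 24.3 ug/mL, and compound 3 `CCOc1cc(/C=C/C(=O)c2ccccc2NC(=O)NS(=O)(=O)c2ccc(C)cc2)ccc1O` gives 19.2 ug/mL. Compound 1 holds the highest of the three numbers, yet the steps that lead away from it stay within the scatter: a 1.2-fold lower number from compound 1 to compound 2 (0.06 log units; within the scatter), and a 1.5-fold lower number from compound 1 to compound 3 (0.17 log units; within the scatter). The step of a 1.3-fold lower number from compound 2 to compound 3 (0.10 log units; within the scatter) is within the scatter as well.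

Compound 4 `Cc1ccc(S(=O)(=O)NC(=O)Nc2ccccc2C(=O)/C=C/c2ccccc2[N+](=O)[O-])cc1` has not been measured in this assay. It differs from compound 1 as follows: 2-nitrophenyl in place of 4-methoxyphenyl on a double-bonded chain carbon bound to a double-bonded chain carbon. The step from compound 1 to compound 3 also replaced the ring on a double-bonded chain carbon bound to a double-bonded chain carbon, and neither it nor the two other measured steps moved the number beyond the scatter. On that basis the step from compound 1 to compound 4 is expected to stay within the scatter too, in no set direction. For compound 4 the expected value in this assay is 26 ug/mL, with a range from 12 ug/mL to 55 ug/mL. This expectation means the step of a 1.1-fold lower number from compound 1 to compound 4 (0.03 log units; within the scatter).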

Compound 4, concentration for half-maximal effect: 40.1 ug/mL
Estimate against measurement, compound 4: 1.5-fold (0.19 log units) below, and the stated range covers the measured number.
By their numbers in this assay, from the lowest: compounds 3, 2, 1 and 4 (each within the scatter of the next, the first and the last beyond it).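

Among these compounds, compound 4 gives the first step that passes beyond the scatter in this assay, and it does so only against one neighbour: a 2.1-fold higher number from compound 3 to compound 4 (0.32 log units; beyond the scatter), while a 1.4-fold higher number from compound 1 to compound 4 (0.15 log units; within the scatter) and a 1.7-fold higher number from compound 2 to compound 4 (0.22 log units; within the scatter) both stay within it. This shows that a ring change on a double-bonded chain carbon bound to a double-bonded chain carbon can move the number measurably, though modestly, and that the size of the step depends on which ring leaves, since only the replacement of 3-ethoxy-4-hydroxyphenyl by 2-nitrophenyl crosses the line. No supporting data bear on why this replacement separates the two compounds.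

The compounds shown leave open whether the higher number of compound 4 belongs to the nitro group itself or to the 2-nitrophenyl ring as a whole, and how an amine or a carboxylic acid would read in place of that nitro group. They also leave open whether a longer chain on the oxygen of the 4-methoxyphenyl ring of compound 1 would shift the number at all.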